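Removing One Chloro Group from a Purine-like Core

A few compounds are considered here, and "the series" means these few. Any claim that something is new, unique, unknown or untested is made for them only; others in the source may bear on it.

Of the compounds shown here, three have been tested so far. Compound 1 `ClCc1ccc(Cn2cnc3nc(Cl)nc(Cl)c32)cc1` and compound 3 `ClCc1ccccc1Cn1cnc2nc(Cl)nc(Cl)c21` share the same atoms joined differently; the difference between the two cores is not broken down here. Compound 2 `ClCc1ccccc1Cn1cnc2ncnc(Cl)c21` is made from compound 3 by the change (hydrogen in place of chloro on an aromatic carbon). Growth inhibition was read in a functional assay on SF-268 cells (Homo sapiens) for cytotoxicity, read by sulforhodamine B assay, with a stated time of 48 h; on this read-out lower numbers stand for stronger inhibition of growth and higher numbers for weaker inhibition of growth. In this assay compound 1 gives 1990 nM, compound 3 gives 3010 nM and compound 2 gives 4780 nM. Among the measured compounds shown here, the one measured step is a 1.6-fold higher number from compound 3 to compound 2 (0.20 log units; within the scatter).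

Compound 4 `ClCc1ccc(Cn2cnc3ncnc(Cl)c32)cc1` has not yet been measured. It differs from compound 1 by hydrogen in place of chloro on an aromatic carbon, the same change that turns compound 3 into compound 2. On that one earlier step, the step to compound 4 is expected to be a 1.6-fold higher number from compound 1 to compound 4 (0.21 log units; within the scatter), because the same change gave a 1.6-fold higher number from compound 3 to compound 2 (0.20 log units; within the scatter). Compound 4 is therefore estimated at about 3200 nM in this assay, with the value expected to fall roughly from 1600 nM to 6400 nM, a range that rests on a single precedent and is wide on purpose.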

Compound 4, concentration for 50% growth inhibition: 1650 nM
Compound 4: the middle estimate sits 1.9-fold (0.29 log units) above what was measured; the range from low to high includes it.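

In this assay, putting hydrogen in place of the chloro group that sits between two ring nitrogen atoms gives a 1.2-fold lower number from compound 1 to compound 4 (0.08 log units; within the scatter), so this change has no readable effect on growth inhibition on the core of compound 1. The two cores agree within what repeated measurements allow: the same change on two cores in this assay, a 1.6-fold higher number (0.20 log units; within the scatter) from compound 3 to compound 2 and a 1.2-fold lower number (0.08 log units; within the scatter) from compound 1 to compound 4, 1.9-fold (0.28 log units) apart, within the scatter of two such steps. This shows that the change carries from one core to the other in the sense that neither step can be told from scatter, but it does not show a direction for the change, and two small steps say nothing firm about any further core.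

Open is how a different group on that same aromatic carbon would behave, such as an amine or a methoxy group, as only chloro and hydrogen appear there in the compounds shown. Also open, going by these compounds, is what would follow if the chloro group that stays in place in all four compounds were exchanged for an amine.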